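Removing a Methyl from Compound 2: What to Expect

The compounds below may be only part of what the source reports. "The series", "measured", "known", "first", "only" and "open" are said of these compounds alone.

Of the compounds shown here, two have been measured in a functional assay on HCT-116 cells (Homo sapiens) for inhibition, read by sulforhodamine B assay, with a stated time of 48 h; on this read-out higher numbers stand for weaker inhibition of growth and lower numbers for stronger inhibition of growth. Compound 1 `COc1cc(-c2nn(-c3cccc(NC(=O)c4ccc(Cl)c(C(F)(F)F)c4)c3)cc2-c2ccncc2)ccc1Cl` gives 2490 nM, and compound 2 `COc1cc(-c2nn(-c3cccc(NC(=O)Nc4ccc(Cl)c(C(F)(F)F)c4)c3)cc2-c2ccncc2)ccc1Cl` gives 1170 nM. Among the measured compounds shown here, the single measured step, a 2.1-fold lower number from compound 1 to compound 2 (0.33 log units; beyond the scatter), concerns the group attached to the carbonyl carbon, and it leaves compound 2 with the lower of the two numbers, compound 1 being its only neighbour. Compound 3 `O=C(Nc1cccc(-n2cc(-c3ccncc3)c(-c3ccc(Cl)c(O)c3)n2)c1)Nc1ccc(Cl)c(C(F)(F)F)c1` differs from compound 2 at a different spot: hydrogen in place of methyl on an oxygen on an aromatic ring. For the measured compounds named here, no measured step touches this oxygen or its methyl, so the data give no direct guide to the size or direction of the change in this assay; the most that can be said is that a step beyond the usual scatter is not expected. Compound 3 is therefore estimated at 1200 nM, within a range from 400 nM to 3600 nM. This estimate corresponds to an expected step of a 1.0-fold higher number from compound 2 to compound 3 (0.01 log units; within the scatter).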

Compound 3, concentration for 50% growth inhibition: 998 nM
Beside the measured number, compound 3's estimate is 1.2-fold (0.08 log units) above it; measured number inside the range.
By their numbers in this assay, from the lowest: compounds 3 and 2 (each within the scatter of the next); then compound 1.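

In this assay, among the compounds shown here, the change from methoxy to hydroxy on the aromatic ring gives a 1.2-fold lower number from compound 2 to compound 3 (0.07 log units; within the scatter), the first measured information on this oxygen. The methyl can therefore be lost without a step beyond the scatter, so the 4-chloro-3-methoxyphenyl and 4-chloro-3-hydroxyphenyl forms cannot be told apart on this read-out, unlike the change at the carbonyl carbon, a 2.1-fold lower number from compound 1 to compound 2 (0.33 log units; beyond the scatter), which lies beyond the scatter. No measurement at hand offers a reason for this result.

As far as these compounds go, it remains open whether a different group on this ring, such as an ethoxy group or an amine in place of the hydroxy, would move the number beyond the scatter. From the compounds shown here alone, it is also open whether methoxy and hydroxy would still read alike in the amide series of compound 1.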